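Replacing 2-methoxyphenyl with pyridin-2-yl in compound 1

The source may hold more compounds than are shown below. What is called first, only, known or untested is meant among the compounds shown, and "the series" means these compounds.

Within the data shown here, in a functional assay on MCF7 cells (Homo sapiens) for antiproliferative activity, read by MTT assay, with a stated time of 48 h (a lower number here means a stronger inhibitor, a higher number a weaker inhibitor), compound 1 `COc1ccccc1N1CCN(C(=O)/C=C/c2ccc(O)c(O)c2)CC1` gives 0.54 ug/mL and holds the lower of the two numbers so far. Compound 2 `O=C(/C=C/c1ccc(O)c(O)c1)N1CCN(c2cccc(C(F)(F)F)c2)CC1` gives 1.24 ug/mL as the higher number, and this gap lies beyond the usual scatter. Among the measured compounds shown here, no step between measured compounds that differ in one place is available, so these two values are the only guide.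

Compound 3 `O=C(/C=C/c1ccc(O)c(O)c1)N1CCN(c2ccccn2)CC1` is the next to be read. It carries pyridin-2-yl in place of 2-methoxyphenyl on an amine nitrogen in a ring and keeps the rest of compound 1 unchanged.

In this assay a modest rise in the number is expected, meaning a somewhat weaker inhibitor, though a result within the scatter of compound 1 remains possible. The reasoning is thin: compound 1 at 0.54 ug/mL is the lowest value known, and compound 2 at 1.24 ug/mL gives the only measure of spread. The expected step is a 1.9-fold higher number from compound 1 to compound 3 (0.27 log units; within the scatter) toward a higher number. For compound 3 the estimate is 1 ug/mL with an expected range from 0.35 ug/mL to 2.8 ug/mL in this read-out.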

Compound 3, half-maximal inhibitory concentration: 1.82 ug/mL
The estimate for compound 3 lay 1.8-fold (0.26 log units) below the measured number, within the range that was stated.
By their numbers in this assay, from the lowest: compound 1; then compounds 2 and 3 (each within the scatter of the next).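

In this assay, among these compounds, the only single-place step so far, a 3.4-fold higher number from compound 1 to compound 3 (0.53 log units; beyond the scatter), shows that the group on this amine nitrogen in a ring matters: pyridin-2-yl in place of 2-methoxyphenyl gives a weaker inhibitor, by a margin that is modest but exceeds the scatter. Compound 1 therefore remains the lowest number of the three, while compounds 2 and 3 stand within the scatter of each other, so the two changes from compound 1 cannot be ranked against each other. The change removes the methoxy group and introduces a ring nitrogen at once, and no measurement on hand explains the rise in the number or separates these two parts of the change.

Plain phenyl at this position would show how much of the step belongs to the methoxy group and how much to the ring nitrogen. An ethoxy group in place of the methoxy group of compound 1 would show whether a longer chain is tolerated there, and how far the lower number of compound 1 depends on the methoxy group itself.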